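The source may report more compounds than this note shows. Statements on the series, on what has been measured and on what is new or still open speak of the compounds shown alone.

Compound 1, `O=C(O)CC/C=C\CC1COC(c2ccc([N+](=O)[O-])cc2)OC1c1cccnc1`, compound 2, `O=C(O)CC/C=C\CC1COC(c2ccc(C(F)(F)F)cc2)OC1c1cccnc1`, and compound 3, `O=C(O)CC/C=C\CC1COC(c2cccs2)OC1c1cccnc1`, share one core and differ only in the group carried on the saturated ring carbon that sits between the two ring oxygen atoms. In an assay for inhibition of Thromboxane-A synthase (Homo sapiens), using microsomes (a higher number here means a weaker inhibitor, a lower number a stronger inhibitor), compound 1 gives 39 nM, compound 2 gives 44 nM, and compound 3 gives 71 nM. Compound 3 thus shows the highest number of the three, yet the steps of a 1.8-fold higher number from compound 1 to compound 3 (0.26 log units; within the scatter) and a 1.6-fold higher number from compound 2 to compound 3 (0.21 log units; within the scatter) both stay within the scatter, as does a 1.1-fold higher number from compound 1 to compound 2 (0.05 log units; within the scatter).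

Compound 4, `O=C(O)CC/C=C\CC1COC(c2ccco2)OC1c1cccnc1`, continues this series at the same position: furan-2-yl in place of thiophen-2-yl on a saturated ring carbon. Among the compounds with values here, the steps that bear on it are those exchanging the aryl group at this carbon, from compound 1 and compound 2 to compound 3, and each was within the scatter even though the groups differ far more than a thiophen-2-yl and a furan-2-yl do. Compound 4 is therefore expected to give a number close to that of compound 3 in this assay, with a step of a 1.1-fold higher number from compound 3 to compound 4 (0.02 log units; within the scatter) that is not expected to exceed the scatter. The estimate for compound 4 is 75 nM, with a range from 35 nM to 170 nM.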

Compound 4, half-maximal inhibitory concentration: 164 nM
Beside the measured number, compound 4's estimate is 2.2-fold (0.34 log units) below it, within the range that was stated.
By their numbers in this assay, from the lowest: compounds 1, 2 and 3 (each within the scatter of the next); then compound 4.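

The carbon between the two ring oxygen atoms is not indifferent to what it carries: furan-2-yl and thiophen-2-yl match in ring size and heavy-atom count, yet the exchange gives a 2.3-fold higher number from compound 3 to compound 4 (0.36 log units; beyond the scatter) in this assay, whereas all the earlier exchanges at this carbon stayed within the scatter. Measured against the two larger groups, furan-2-yl gives a 3.7-fold higher number from compound 2 to compound 4 (0.57 log units; beyond the scatter) and a 4.2-fold higher number from compound 1 to compound 4 (0.62 log units; beyond the scatter), which sets compound 4 apart from compounds 1, 2 and 3, themselves within the scatter of one another. Nothing available explains this difference.

From the compounds shown here alone, it remains open whether an unsubstituted phenyl or a furan-3-yl group at this carbon would fall with compounds 1, 2 and 3 or with compound 4. Going by these compounds, it is also open whether the gap between furan-2-yl and thiophen-2-yl would persist if a longer chain replaced the 5-carboxypent-2-en-1-yl group.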